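The source may report more compounds than this note shows. Statements on the series, on what has been measured and on what is new or still open speak of the compounds shown alone.

In a functional assay on PANC-1 cells (Homo sapiens) for antiproliferative activity, read by MTT assay, with a stated time of 48 h (a lower number here means a stronger inhibitor, a higher number a weaker inhibitor), compound 1 `Cc1c(C(=O)NCCCN(C)C)oc2ccc(N(Cc3ccc(Br)cc3)S(=O)(=O)c3ccc(Br)cc3)cc12` gives 2300 nM, and compound 2 `Cc1c(C(=O)OCCCN(C)C)oc2ccc(N(Cc3ccc(Br)cc3)S(=O)(=O)c3ccc(Br)cc3)cc12` gives 24600 nM, the higher and so weaker of the two. Compound 3 `Cc1c(C(=O)NCCS(C)(=O)=O)oc2ccc(N(Cc3ccc(Br)cc3)S(=O)(=O)c3ccc(Br)cc3)cc12` carries (2-(methylsulfonyl)ethyl)amino in place of 3-(dimethylamino)propoxy on a carbonyl carbon. Within the data shown here, the one measured step that bears on this is a large one, an 11-fold higher number from compound 1 to compound 2 (1.03 log units; beyond the scatter), with 3-(dimethylamino)propoxy in place of (3-(dimethylamino)propyl)amino. Among the measured compounds shown here, compound 3 shares an amino on the carbonyl with compound 1, but its chain differs, and no measured step isolates that change. A smaller move to a lower number is therefore expected, a 3.1-fold lower number from compound 2 to compound 3 (0.49 log units; beyond the scatter). The estimated value for compound 3 is 8000 nM, with an expected range of 2500 nM to 25000 nM.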

Compound 3, half-maximal inhibitory concentration: > 40000 nM
Compound 3: no number, only a limit; the forecaster's own chance of this, stated with the estimate: 5%; middle value at least 5.0-fold (0.69 log units) from the limit.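

In this assay compound 3 gives no number, only a limit: the limit of > 40000 nM in this assay, at which 1 of the 3 values shown sits. The step that changes only the end of the amide chain is an at least 17-fold higher number from compound 1 to compound 3 (1.24 log units; beyond the scatter), with methylsulfonyl in place of (dimethylamino)methyl, so an amino link on the carbonyl does not by itself keep the activity, and the chain end matters as well. The other step, an at least 1.6-fold higher number from compound 2 to compound 3 (0.21 log units; that floor lies within the scatter), gives only a floor, so it cannot set these two apart.

As far as these compounds go, it remains open whether a chain ending in a primary amine or a morpholine would serve as well as one ending in dimethylamino.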